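The source may hold more compounds than are shown below. What is called first, only, known or untested is meant among the compounds shown, and "the series" means these compounds.

Measured in a functional assay on MGC-803 cells (Homo sapiens) for inhibition, read by MTT assay, with a stated time of 72 h, tested at 10 uM; a lower number here means less inhibition of growth, a higher number more inhibition of growth at the concentration tested:

compound 1 `O=C(/C=C/c1ccccc1Oc1ncnc2ccc(Cl)cc12)/C=C/c1c(Cl)cccc1Cl`: 69.3%
compound 2 `O=C(/C=C/c1ccc(Oc2ncnc3ccc(Cl)cc23)cc1)/C=C/c1ccc(Cl)c(Cl)c1`: 50.5%
compound 3 `O=C(/C=C/c1ccc(Cl)c(Cl)c1)/C=C/c1ccccc1Oc1ncnc2ccc(Cl)cc12`: 56.7%

Compound 2 has the lowest of the three numbers in this assay. Its nearest neighbour is compound 3, whose value lies within the scatter of that of compound 2; compound 1 stands furthest away, higher and beyond the scatter.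

Compound 4 `O=C(/C=C/c1ccc(Oc2ncnc3ccc(Cl)cc23)cc1)/C=C/c1cc([N+](=O)[O-])ccc1Cl` is not yet measured. It differs from compound 2 in one place: 2-chloro-5-nitrophenyl in place of 3,4-dichlorophenyl on a double-bonded chain carbon bound to a double-bonded chain carbon

For the measured compounds named here, the only measured step in this set, a number 12.6 percentage points lower from compound 1 to compound 3 (beyond the scatter), concerns a different exchange on the same position and gives only a loose sense of what a change of the aryl group at this site can do. Going by the values given here, no measured pair shows the entry of a 2-chloro-5-nitrophenyl group, so the direction cannot be read from the data. A step of about the size of the known one, in either direction, or none beyond the scatter, is the reasonable expectation; the estimate is centred on no change. Compound 4 is therefore expected at 50% in this assay, with a range from 35% to 65%, meaning an expected step of a number 0.5 percentage points lower from compound 2 to compound 4 (within the scatter).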

Compound 4, percent growth inhibition at one concentration: 86.7%
Estimate against measurement, compound 4: 36.7 percentage points below; measured number outside the range, above it.
By their numbers in this assay, from the lowest: compounds 2 and 3 (each within the scatter of the next); then compound 1; then compound 4.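

In this assay, for the compounds shown here, the change at the double-bonded chain carbon gives a number 36.2 percentage points higher from compound 2 to compound 4 (beyond the scatter) and so shows for the first time that an aryl exchange at this place can raise the number. Going by these compounds alone, the only earlier step, a number 12.6 percentage points lower from compound 1 to compound 3 (beyond the scatter), was a modest drop and a different exchange on a different compound, while this one is large, so the choice of aryl group here can matter far more than that step suggested. No measured evidence bears on the reason for the rise.

The exchange alters the chlorine pattern and adds the nitro group at once, so the compounds shown do not separate the two contributions. Also open, on these data alone, are whether an amine or a carboxylic acid in place of the nitro group would hold the higher number, and whether 2-chloro-5-nitrophenyl gives a similar rise on compound 3.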